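The source may report more compounds than this note shows. Statements on the series, on what has been measured and on what is new or still open speak of the compounds shown alone.

Working notes on the series. Of the compounds shown here, two carry numbers so far. Compound 1 `CC(C)(C)c1cc(OC(=O)c2ccc(Cl)cc2Cl)ccc1O` is the ester; in an assay on isolated protein for antagonist activity at Bile acid receptor (Homo sapiens), read by HTRF, with a stated time of 30 min (on this read-out lower numbers stand for stronger inhibition and higher numbers for weaker inhibition), compound 1 gives 10200 nM. Compound 2 `CC(C)(C)c1cc(NC(=O)c2c(Cl)cc(N)cc2Cl)ccc1O` is the amide with a free amino group on the chlorinated ring; in this assay compound 2 gives 5200 nM. For the measured compounds named here, the two numbers lie within the scatter of each other, so no ordering between compound 1 and compound 2 is claimed here, and the ester-to-amide change carries no step of its own in these data.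

The next compound, compound 3 `CC(C)(C)c1cc(NC(=O)c2c(Cl)cc(NCc3ccncc3)cc2Cl)ccc1O`, differs from compound 2 in one place: (pyridin-4-yl)methyl in place of hydrogen on a nitrogen on an aromatic ring. Going by the values given here, no measured pair isolates a change of this kind, so the size of the effect rests on expectation alone. The step from compound 2 to compound 3 in this assay is expected to be a 2.1-fold lower number from compound 2 to compound 3 (0.32 log units; beyond the scatter), a modest gain that may not clear the scatter. Compound 3 is thus estimated at 2500 nM in this assay, with a range from 800 nM to 8000 nM.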

Compound 3, half-maximal inhibitory concentration: 9800 nM
Beside the measured number, compound 3's estimate is 3.9-fold (0.59 log units) below it; the whole stated range lies below it.
By their numbers in this assay, from the lowest: compounds 2, 3 and 1 (each within the scatter of the next).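

In this assay the new substituent gives a 1.9-fold higher number from compound 2 to compound 3 (0.28 log units; within the scatter), with (pyridin-4-yl)methyl in place of hydrogen on a nitrogen on an aromatic ring. For the compounds shown here, this nitrogen therefore accepts a group carrying a six-membered aromatic ring with no step that clears the scatter, something not visible while compound 2, with its plain amino group, was the only compound with a free or substituted nitrogen at this place. Nothing in hand offers an explanation for this result. Going by these compounds, whether a small group such as methyl, or a longer chain ending in a carboxylic acid, would give a step beyond the scatter from compound 2 remains open. Also open, on these data alone, is what the ring nitrogen contributes, which phenylmethyl at the same place would test.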